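Trimethoxyphenyl to methoxyphenyl on the shared core

The source may report more compounds than this note shows. Statements on the series, on what has been measured and on what is new or still open speak of the compounds shown alone.

Compound 3 `COc1ccc(C(=O)/C=C/c2cc(-c3cc(OC)c(OC)c(OC)c3)n3nc(-c4ccccc4)cc3n2)cc1OC` gives the highest of the three numbers in an ADME assay on HEK293 cells (Homo sapiens) for antiproliferative activity, read by MTT assay, with a stated time of 24 h (a lower number here means a stronger inhibitor, a higher number a weaker inhibitor), at 81700 nM. Compound 2 `COc1cc(/C=C/C(=O)c2cc(-c3cc(OC)c(OC)c(OC)c3)n3nc(-c4ccccc4)cc3n2)cc(OC)c1OC` gives 41000 nM, within the scatter of compound 3. Compound 1 `COc1ccc(-c2cc(/C=C/C(=O)c3cc(OC)c(OC)c(OC)c3)nc3cc(-c4ccccc4)nn23)cc1OC` gives 35000 nM, a gap beyond the scatter, so the series as a whole sits at weak inhibition in this assay. Compound 4 `COc1ccc(-c2cc(/C=C/C(=O)c3ccc(OC)c(OC)c3)nc3cc(-c4ccccc4)nn23)cc1` differs from compound 3 by one change: 4-methoxyphenyl in place of 3,4,5-trimethoxyphenyl on an aromatic carbon. No pair among the measured compounds isolates this change, so nothing on its size is known from the shown numbers. The step of a 1.4-fold lower number from compound 3 to compound 4 (0.13 log units; within the scatter) is expected to stay within the scatter, with no clear direction. Compound 4 is therefore estimated at 60000 nM, with a range from 25000 nM to 150000 nM.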

Compound 4, half-maximal inhibitory concentration: 48500 nM
Beside the measured number, compound 4's estimate is 1.2-fold (0.09 log units) above it, and the stated range covers the measured number.
By their numbers in this assay, from the lowest: compounds 1, 2, 4 and 3 (each within the scatter of the next, the first and the last beyond it).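

In this assay the swap to 4-methoxyphenyl from 3,4,5-trimethoxyphenyl, on the aromatic carbon next to the ring nitrogen, can now be read directly: a 1.7-fold lower number from compound 3 to compound 4 (0.23 log units; within the scatter) and thus no clear effect of this change. This position accepts the smaller aryl group without a clear shift, and the number stays in the weak range of the series. No further measurement bears on this result.

Still open, going by these compounds, is whether an amine or a carboxylic acid on this phenyl ring, or a longer alkyl chain in its place, would move the number beyond the scatter.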